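This account rests on a few compounds, and the source may have more. Where it says the series, first, only, none or still open, it means among the compounds named here.

The measured compounds in an ADME assay on RAW264.7 cells (Mus musculus) for cytotoxicity, read by MTT assay, with a stated time of 48 h, tested at 50 uM; a lower number here means less inhibition, a higher number more inhibition at the concentration tested (going by the name of the read-out):
compound 1 `N=C1S/C(=C\c2ccc(OCc3ccccc3)cc2)C(=O)N1c1ccc([N+](=O)[O-])cc1`, 17.3%
compound 2 `N=C1S/C(=C\c2ccc(OCc3ccccc3)cc2)C(=O)N1c1ccc(Cl)cc1Cl`, 13.8%
compound 3 `N=C1S/C(=C\c2ccc(OCc3ccccc3)cc2)C(=O)N1c1ccccn1`, 37.2%

Compound 3 stands highest of the three in this assay; compound 1 is the nearest to it and compound 2 the furthest, both beyond the scatter. Compound 4 `Cc1ccc(C)c(N2C(=N)S/C(=C\c3ccc(OCc4ccccc4)cc3)C2=O)c1` has not been measured. It differs from compound 3 in one place: 2,5-dimethylphenyl in place of pyridin-2-yl on an amide-type nitrogen in a ring. For the measured compounds named here, two measured steps bear on this change, each replacing a ring of carbon only by pyridin-2-yl on the amide-type nitrogen in the ring: a number 19.9 percentage points higher from compound 1 to compound 3 (beyond the scatter) and a number 23.4 percentage points higher from compound 2 to compound 3 (beyond the scatter). The remaining step, a number 3.5 percentage points lower from compound 1 to compound 2 (within the scatter), shows that the two compounds carrying a ring of carbon only give numbers within the scatter of each other. Going by the values given here, compound 4 moves back from pyridin-2-yl to a ring of carbon only, so the earlier steps are read in reverse. Compound 4 is therefore expected to come out lower than compound 3, as a number 21.2 percentage points lower from compound 3 to compound 4 (beyond the scatter). Compound 4 is estimated at 16%, with a range from 5% to 30%.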

Compound 4, a percentage reported as inhibition, at one concentration (the size of the read-out at that concentration, not a potency): 45.8%
The estimate for compound 4 lay 29.8 percentage points below the measured number, outside the stated range (above it).
By their numbers in this assay, from the lowest: compounds 2 and 1 (each within the scatter of the next); then compounds 3 and 4 (each within the scatter of the next).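

In this assay, the result shows that a ring of carbon only on the amide-type nitrogen does not by itself keep the number low: replacing pyridin-2-yl with 2,5-dimethylphenyl gives a number 8.6 percentage points higher from compound 3 to compound 4 (within the scatter), so the two groups are not told apart here. The rings of carbon only also no longer read alike, with a number 32 percentage points higher from compound 2 to compound 4 (beyond the scatter) and a number 28.5 percentage points higher from compound 1 to compound 4 (beyond the scatter), so at this position the groups carried on such a ring matter, and the presence or absence of a ring nitrogen does not settle the number. Nothing available here explains these differences.

The compounds shown leave open whether the number for compound 4 needs both methyl groups or only one. They also leave open how a carboxylic acid, a morpholine or an unbranched alkyl chain on the same nitrogen would read.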